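This account rests on a few compounds, and the source may have more. Where it says the series, first, only, none or still open, it means among the compounds named here.

Of the compounds shown here, three that share a common core have been tested in a functional assay on HepG2 cells (Homo sapiens) for inhibition, read by MTT assay, with a stated time of 72 h; a lower number here means a stronger inhibitor, a higher number a weaker inhibitor. Compound 1, `CN(C(=O)NC(=O)c1ccccc1F)c1nc(C(F)(F)F)c(C(=O)N/N=C/c2ccc(C(F)(F)F)cc2)s1`, gives 4.56 ug/mL. Compound 3, `CN(C(=O)NC(=O)c1ccc(Cl)c(Cl)c1)c1nc(C(F)(F)F)c(C(=O)N/N=C/c2ccc([N+](=O)[O-])cc2)s1`, gives 6.85 ug/mL. Compound 2, `Cc1nc(N(C)C(=O)NC(=O)c2c(F)cccc2F)sc1C(=O)N/N=C/c1ccccc1F`, reaches only a limit rather than a number, reported as > 100 ug/mL. That boundary is the limit of > 100 ug/mL in this assay, at which 1 of the 3 values shown sits. Of the two real numbers shown, compound 3 carries the higher one, yet its nearest neighbour, compound 1, sits within the usual scatter of it, so the two cannot be placed in order.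

Compound 4, `CN(C(=O)NC(=O)c1ccc(F)c(F)c1)c1nc(C(F)(F)F)c(C(=O)N/N=C/c2ccc([N+](=O)[O-])cc2)s1`, has not yet been measured. It differs from compound 3 in a single place: 3,4-difluorophenyl in place of 3,4-dichlorophenyl on a carbonyl carbon. Within the data shown here, no measured pair shows this same exchange, so its effect in this assay can only be anticipated. Replacing 3,4-dichlorophenyl with 3,4-difluorophenyl on a carbonyl carbon seems likely to shift the number only modestly, perhaps a small rise toward a weaker inhibitor, though a step that stays inside the scatter would be no surprise. Compound 4 is therefore expected to give about 10 ug/mL, within a range from 3 ug/mL to 40 ug/mL, which amounts to an estimated step of a 1.5-fold higher number from compound 3 to compound 4 (0.16 log units; within the scatter).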

Compound 4, half-maximal inhibitory concentration: 6.23 ug/mL
Compound 4: middle estimate off by 1.6-fold (0.21 log units), on the high side; low and high end bracket the measured number.
By their numbers in this assay, from the lowest: compounds 1, 4 and 3 (each within the scatter of the next). At a limit, above all of these: compound 2.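

In this assay, among these compounds, this pair gives the first direct reading of a change on this carbonyl carbon, because compounds 1, 2 and 3 each differ from one another in more than one place: 3,4-difluorophenyl in place of 3,4-dichlorophenyl gives a 1.1-fold lower number from compound 3 to compound 4 (0.04 log units; within the scatter). With everything else in the molecule held fixed, the two rings cannot be told apart in this assay, so this one exchange leaves the number inside the usual scatter of repeated measurements. Nothing measured here offers an explanation for that lack of separation.

The compounds shown leave open whether a more different group on this carbonyl carbon, such as a 3,4-dimethoxyphenyl ring or a saturated cyclohexyl ring, would move the number beyond the scatter. On these data alone, it also remains unknown whether the exchange of 3,4-dichlorophenyl for 3,4-difluorophenyl would read the same way if the molecule were changed elsewhere.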